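The source may hold more compounds than are shown below. What is called first, only, known or untested is meant among the compounds shown, and "the series" means these compounds.

Measured in a functional assay on ECa-109 cells for inhibition, with ECa-109 cell line (Homo sapiens) as the target, read by sulforhodamine B assay; a lower number here means a stronger inhibitor, a higher number a weaker inhibitor:
compound 1, `O=C1C(N2CCCCC2)=CC(=O)c2c1nc1n2[C@H]2OC[C@@H](O)[C@H]2OC1`: > 8000 nM
compound 2, `O=C1C=C(Nc2ccc(C(F)(F)F)cc2)C(=O)c2c1nc1n2[C@H]2OC[C@@H](O)[C@H]2OC1`: 5500 nM
compound 3, `CCOc1ccccc1NC1=CC(=O)c2c(nc3n2[C@H]2OC[C@@H](O)[C@H]2OC3)C1=O`: 4320 nM

The value of compound 1 is a limit of this assay and not a number. Of the two numbers, compound 2 holds the higher, with compound 3 within the scatter of it, so no order between the two can be read. Compound 4, `O=C1C=C(Nc2ccc(Br)cc2)C(=O)c2c1nc1n2[C@H]2OC[C@@H](O)[C@H]2OC1`, is not yet measured. It differs from compound 2 in one place: bromo in place of trifluoromethyl on an aromatic carbon. No measured pair carries this change, so its step in this assay is unknown; nothing among the numbers shown points in either direction, and a step no larger than the scatter is expected. For compound 4 the expected value is 5000 nM, between 2000 nM and 12000 nM. The expected step, a 1.1-fold lower number from compound 2 to compound 4 (0.04 log units; within the scatter), stays within the scatter.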

Compound 4, half-maximal inhibitory concentration: 2850 nM
Compound 4: the middle estimate sits 1.8-fold (0.24 log units) above what was measured; the range from low to high includes it.
By their numbers in this assay, from the lowest: compounds 4, 3 and 2 (each within the scatter of the next). At a limit, above all of these: compound 1.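

Going by these compounds alone, this is the only one-place comparison so far. In this assay, replacing 4-(trifluoromethyl)phenyl with 4-bromophenyl gives a 1.9-fold lower number from compound 2 to compound 4 (0.29 log units; within the scatter), so at this position on the aromatic ring the two groups cannot be told apart, though the step is large for one within the scatter. Nothing measured here bears on what lies behind this step.

Still open, as far as these compounds go, is how a carboxylic acid or a dimethylamino group would read at this same place. Chloro and methoxy there are also open.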